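Tert-Butyl in Place of Chloro on the Aromatic Ring

The compounds below may be only part of what the source reports. "The series", "measured", "known", "first", "only" and "open" are said of these compounds alone.

Compound 1 `NC1=NC2(CCOCC2)N(OCCCOc2ccc(Cl)cc2)C(N)=N1` was examined in an assay on isolated protein for inhibition of Dihydrofolate reductase (Homo sapiens), read by spectrophotometry, using NADPH, with stated times of 5 s and 6 min (on this read-out higher numbers stand for weaker inhibition and lower numbers for stronger inhibition), where compound 1 gives 33.6 nM. Of the two numbers available it is the higher; the nearest, compound 3 `NC1=NC2(CCOCC2)N(OCCCOc2ccc(Cl)cc2Cl)C(N)=N1`, gives 7.46 nM, the step of a 4.5-fold lower number from compound 1 to compound 3 (0.65 log units; beyond the scatter) arising from chloro in place of hydrogen on an aromatic carbon. Compound 2 `NC1=NC2(CCOCC2)N(OCCCOc2ccccc2Cl)C(N)=N1` has "not determined" (no result reported) in this assay. Compound 4 `CC(C)(C)c1ccc(OCCCON2C(N)=NC(N)=NC23CCOCC3)cc1` differs from compound 1 by tert-butyl in place of chloro on an aromatic carbon. For the measured compounds named here, the one measured step adds a second chloro; no measured step exchanges the existing chloro for another group, so it offers no direct guide. Lacking a parallel, the step of a 1.1-fold lower number from compound 1 to compound 4 (0.05 log units; within the scatter) is expected to remain within the scatter. Compound 4 is therefore estimated at 30 nM, between 10 nM and 100 nM.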

Compound 4, half-maximal inhibitory concentration: 3.72 nM
Compound 4: middle estimate off by 8.1-fold (0.91 log units), on the high side; measured number below the stated range.
By their numbers in this assay, from the lowest: compounds 4 and 3 (each within the scatter of the next); then compound 1.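

Exchanging chloro for tert-butyl gives a 9.0-fold lower number from compound 1 to compound 4 (0.96 log units; beyond the scatter) in this assay and shows that this place on the ring tolerates a group of 4 heavy atoms in place of 1. The earlier step only added a second chloro, while this one replaces the group already present, and the larger group carries the lower number. Nothing measured here accounts for this step.

As far as these compounds go, it remains open how an amine, a carboxylic acid or a methoxy group would fare at this place. From the compounds shown here alone, it also remains open whether adding a chloro to compound 4 would lower the number further.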